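A few compounds are considered here, and "the series" means these few. Any claim that something is new, unique, unknown or untested is made for them only; others in the source may bear on it.

Of the compounds shown here, three sharing one core have been measured in a functional assay on SW-620 cells (Homo sapiens) for cytotoxicity, read by sulforhodamine B assay, with a stated time of 48 h; on this read-out higher numbers stand for weaker inhibition and lower numbers for stronger inhibition. Compound 1 `C[C@H]1CC[C@@H]2[C@@H](OC(=O)[C@]23CC(c2ccccc2)=NO3)[C@]2(C)C(=O)C=C[C@@]12O` gives 45400 nM, compound 2 `Cc1ccccc1C1=NO[C@]2(C1)C(=O)O[C@@H]1[C@H]2CC[C@H](C)[C@]2(O)C=CC(=O)[C@@]12C` gives 5000 nM, and compound 3 `Cc1cccc(C2=NO[C@]3(C2)C(=O)O[C@@H]2[C@H]3CC[C@H](C)[C@]3(O)C=CC(=O)[C@@]23C)c1` gives 15000 nM. Compound 3 therefore holds the second highest of the three numbers, and its gaps to both neighbours lie beyond the scatter.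

Compound 4 `C[C@H]1CC[C@@H]2[C@@H](OC(=O)[C@]23CC(c2ccc(F)cc2)=NO3)[C@]2(C)C(=O)C=C[C@@]12O` has not yet been measured. It carries 4-fluorophenyl in place of 3-methylphenyl on a carbon with a double bond to nitrogen.

Within the data shown here, three measured steps bear on this change, all of them modest. Methyl in place of hydrogen on an aromatic carbon gave a 9.1-fold lower number from compound 1 to compound 2 (0.96 log units; beyond the scatter) and a 3.0-fold lower number from compound 1 to compound 3 (0.48 log units; beyond the scatter). The swap of 2-methylphenyl for 3-methylphenyl gave a 3.0-fold higher number from compound 2 to compound 3 (0.48 log units; beyond the scatter). Compound 4 lacks the methyl of compound 3, which points towards the higher number of compound 1 at 45400 nM. Among the measured compounds shown here, no measured compound carries fluorine, however, so the effect of that atom is unknown, and a lowering like that seen with methyl remains possible. A small upward move, not beyond the scatter, is therefore expected in this assay. The expected change is a 1.3-fold higher number from compound 3 to compound 4 (0.12 log units; within the scatter). The estimated value for compound 4 is 20000 nM, with an expected range of 7000 nM to 55000 nM.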

Compound 4, half-maximal inhibitory concentration: 3600 nM
Beside the measured number, compound 4's estimate is 5.6-fold (0.74 log units) above it; the measured number lies below the stated range.
By their numbers in this assay, from the lowest: compounds 4 and 2 (each within the scatter of the next); then compound 3; then compound 1.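

In this assay, fluoro in place of hydrogen on the aromatic carbon gives a 13-fold lower number from compound 1 to compound 4 (1.10 log units; beyond the scatter) and is the only large step among these compounds, so methyl is not the only substituent on this phenyl ring that goes with a lower number. The change from 3-methylphenyl to 4-fluorophenyl on the carbon with a double bond to nitrogen gives a 4.2-fold lower number from compound 3 to compound 4 (0.62 log units; beyond the scatter) and shows that the identity of this aryl group still matters among substituted rings, whereas a 1.4-fold lower number from compound 2 to compound 4 (0.14 log units; within the scatter) stays within the scatter, leaving 2-methylphenyl and 4-fluorophenyl indistinguishable in this assay. Nothing available here explains why this change has the effect seen.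

What the compounds shown leave open is whether the lower numbers depend on fluorine or methyl specifically, or would also appear with a chloro group, a methoxy group, an amine or a carboxylic acid on the same phenyl ring. As far as these compounds go, it also remains open whether a fluoro group would give a similar number at another place on that ring, and how any of these results would carry over to other cell lines.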